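The source may report more compounds than this note shows. Statements on the series, on what has been measured and on what is new or still open speak of the compounds shown alone.

Within the data shown here, compound 2, `COc1ccccc1-c1cccc(CNc2ccc(OCC(=O)O)c(F)c2)c1`, gives 536 nM in a functional assay on CHO cells for agonist activity at Free fatty acid receptor 1 (Homo sapiens), read by FLIPR and calcium flux (on this read-out lower numbers stand for an effect already at smaller amounts and higher numbers for an effect only at larger amounts of compound), the highest of the two numbers known here; the nearest is compound 1, `O=C(O)COc1ccc(NCc2cccc(-c3ccccc3Cl)c2)cc1F`, which gives 19.3 nM. Among the measured compounds shown here, the one step between them, a 28-fold higher number from compound 1 to compound 2 (1.44 log units; beyond the scatter), came with a single change, methoxy in place of chloro on an aromatic carbon. Compound 3, `CCOc1ccc(-c2cccc(CNc3ccc(OCC(=O)O)c(F)c3)c2)c(C)c1`, has not yet been measured; it differs from compound 2 by 4-ethoxy-2-methylphenyl in place of 2-methoxyphenyl on an aromatic carbon. For the measured compounds named here, no measured step covers this exact change, so only the step from compound 1 to compound 2 can guide the expectation, and it shows that the identity of the group on this ring can move the number a long way. Compound 3 is therefore expected to give a lower number than compound 2, with a 5.4-fold lower number from compound 2 to compound 3 (0.73 log units; beyond the scatter) as the estimated step. The estimate for compound 3 is 100 nM, within a range from 20 nM to 500 nM.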

Compound 3, half-maximal effective concentration: 11.6 nM
For compound 3 the middle estimate is 8.6-fold (0.94 log units) above the measured one, and the stated range ends above it.
By their numbers in this assay, from the lowest: compounds 3 and 1 (each within the scatter of the next); then compound 2.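

In this assay, the step of a 46-fold lower number from compound 2 to compound 3 (1.66 log units; beyond the scatter) shows that a high number at this aromatic carbon can be fully reversed by changing the aryl group, here to 4-ethoxy-2-methylphenyl, while an oxygen-bearing group remains in place. The step of a 1.7-fold lower number from compound 1 to compound 3 (0.22 log units; within the scatter) leaves the 2-chlorophenyl and 4-ethoxy-2-methylphenyl groups unseparated, so an ether oxygen on this ring does not by itself go with a high number. Nothing given here accounts for either step.

The change brings in the ethoxy and the methyl together, so the compounds shown leave open how much of the step belongs to each, as a 4-ethoxyphenyl or a 2-methylphenyl group would show. Also open, from the compounds shown here alone, is how a longer chain such as butoxy, or an amine, would fare on this ring.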